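This account rests on a few compounds, and the source may have more. Where it says the series, first, only, none or still open, it means among the compounds named here.

Compound 1 `CC#C[C@H]1CN(S(=O)(=O)c2ccc(N)nc2)CCN1c1ccc(C(O)(C(F)(F)F)C(F)(F)F)cn1`: 42 mL.min-1.g-1
Compound 2 `CC#CCC(O)(c1ccc(N2CCN(S(=O)(=O)c3ccc(N)nc3)C[C@@H]2C#CC)cc1)C(F)(F)F`: 115 mL.min-1.g-1
Compound 3 `CC#C[C@H]1CN(S(=O)(=O)c2ccc(N)nc2)CCN1c1ccc(S(=O)(=O)NC)cn1`: 42 mL.min-1.g-1

All three were run in an ADME assay (liver) for metabolic stability, with Liver microsome (Rattus norvegicus) as the target, using microsomes and NADPH, with a stated time of 30 min; on this read-out higher numbers stand for fast clearance and lower numbers for slow clearance. Compound 2 has the highest number of the three; compound 1 is its nearest neighbour and compound 3 lies just as far below it, both gaps beyond the scatter. Within the data shown here, the single step between compounds that differ in one place, no change at the digits printed from compound 1 to compound 3 (within the scatter), exchanges one group on an aromatic carbon for another without moving the read-out.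

Compound 4 `CC#C[C@H]1CN(S(=O)(=O)c2ccc(N)nc2)CCN1c1ccc(S(=O)(=NC)C(F)(F)F)cc1` has not yet been measured. It differs from compound 2 as follows: a group of 8 heavy atoms (2 carbon, 1 nitrogen, 1 oxygen, 3 fluorine, 1 sulfur; no ring) in place of a group of 10 heavy atoms (6 carbon, 1 oxygen, 3 fluorine; no ring), on an aromatic carbon. Among the measured compounds shown here, no measured step matches this exchange directly. The step from compound 1 to compound 3 bears on it only loosely, showing that swapping the group on an aromatic carbon can leave the read-out unchanged, while compound 1 and compound 3, each carrying a different group on that aromatic carbon, sit well below compound 2. A downward step is therefore expected: a 2.6-fold lower number from compound 2 to compound 4 (0.41 log units; beyond the scatter). Compound 4 is expected to give 45 mL.min-1.g-1, within a range of 22 mL.min-1.g-1 to 95 mL.min-1.g-1.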

Compound 4, intrinsic clearance in microsomes: 257 mL.min-1.g-1
Beside the measured number, compound 4's estimate is 5.7-fold (0.76 log units) below it; measured number above the stated range.
By their numbers in this assay, from the lowest: compounds 1 and 3 (each within the scatter of the next); then compound 2; then compound 4.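

Exchanging the group on this aromatic carbon, para to a large group, is not always neutral in this assay: the change gives a 2.2-fold higher number from compound 2 to compound 4 (0.35 log units; beyond the scatter), whereas the earlier exchange gave no change at the digits printed from compound 1 to compound 3 (within the scatter). The group that leaves compound 2 carries a triple bond and a hydrogen-bond donor and the group that enters has neither, so in this pair losing both went with faster clearance, not slower. Nothing available here accounts for the rise.

Still open, going by these compounds, is whether the group that enters compound 4 would raise the number on the core of compound 1 as well, or whether the rise belongs to this pair alone. Also open, on these data alone, is how a methylsulfonyl group or a carboxylic acid on the same aromatic carbon would read in this assay.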